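The source may report more compounds than this note shows. Statements on the series, on what has been measured and on what is new or still open speak of the compounds shown alone.

Three measured compounds share one core. Compound 1 `CC(C)c1ccccc1OS(=O)(=O)c1cccc(NC(=O)CCCl)c1` gives 12000 nM in a functional assay on MCF7 cells (Homo sapiens) for antiproliferative activity, read by sulforhodamine B assay, with a stated time of 48 h; a lower number here means a stronger inhibitor, a higher number a weaker inhibitor. Compound 2 `CCCCCC(=O)Nc1ccc(S(=O)(=O)Oc2ccccc2C(C)C)cc1` gives 5300 nM, and compound 3 `CCCCCC(=O)Nc1ccc(S(=O)(=O)Oc2ccccc2I)cc1` gives 10000 nM; all three values lie within the scatter of one another, so none can be called stronger or weaker. Among the measured compounds shown here, the only step recorded, a 1.9-fold higher number from compound 2 to compound 3 (0.28 log units; within the scatter), concerns the aromatic substituent. Compound 4 `CCCNC(=O)Nc1ccc(S(=O)(=O)Oc2ccccc2I)cc1` differs from compound 3 in another place: propylamino in place of pentyl on a carbonyl carbon. For the measured compounds named here, no measured step changes this carbonyl substituent, so there is no direct guide; with every value so far within one band, a step of no more than the scatter is expected, no change at the digits printed from compound 3 to compound 4 (within the scatter). Compound 4 is therefore estimated at 10000 nM, within 3500 nM to 30000 nM.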

Compound 4, half-maximal inhibitory concentration: 2900 nM
Estimate against measurement, compound 4: 3.4-fold (0.54 log units) above; the measured number lies below the stated range.
By their numbers in this assay, from the lowest: compounds 4, 2, 3 and 1 (each within the scatter of the next, the first and the last beyond it).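

In this assay, among the compounds shown here, the group on this carbonyl carbon proves able to move the number: propylamino in place of pentyl gives a 3.4-fold lower number from compound 3 to compound 4 (0.54 log units; beyond the scatter) as the first step here beyond the scatter, though a modest one. The earlier compounds shown here, all within the scatter of one another, did not show this. Nothing available explains the shift. From the compounds shown here alone, two things change together, the chain and the new nitrogen with its hydrogen-bond donor, so their shares stay open. Pentylamino or butyl on the same carbonyl carbon would help separate them.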